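From a substituted furan to 2-methoxyphenyl on a carbonyl carbon

The compounds below may be only part of what the source reports. "The series", "measured", "known", "first", "only" and "open" are said of these compounds alone.

In a functional assay on HCT-116 cells (Homo sapiens) for antiproliferative activity, read by resazurin assay, with a stated time of 5 days (on this read-out higher numbers stand for weaker inhibition and lower numbers for stronger inhibition), compound 1 (`O=C(NO)c1cc2ccc(CN3CCc4ccccc4C3)c(F)c2s1`) reads 3000 nM and compound 2 (`O=C(NCc1ccc2cc(C(=O)NO)sc2c1F)c1ccco1`) reads 90 nM on the same scale. Compound 3 (`Cc1cc(C(=O)NCc2ccc3cc(C(=O)NO)sc3c2F)oc1C`) reads 470 nM and so holds the second highest of the three numbers, with compound 2 lower and compound 1 higher.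

Compound 4 (`COc1ccccc1C(=O)NCc1ccc2cc(C(=O)NO)sc2c1F`) is still unmeasured. It carries 2-methoxyphenyl in place of 4,5-dimethylfuran-2-yl on a carbonyl carbon.

Among the measured compounds shown here, the one measured step at this place is a 5.2-fold higher number from compound 2 to compound 3 (0.72 log units; beyond the scatter) with 4,5-dimethylfuran-2-yl in place of furan-2-yl. For the measured compounds named here, that step shows the number can move with the group here, but no measured compound has a six-membered aromatic ring at this place, so it speaks to size more than direction. The step expected at the middle of the estimate is a 1.6-fold lower number from compound 3 to compound 4 (0.19 log units; within the scatter) and is therefore small next to the measured one. For compound 4 the estimated value is 300 nM with an expected range from 100 nM to 900 nM overall.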

Compound 4, half-maximal inhibitory concentration: 1200 nM
Beside the measured number, compound 4's estimate is 4.0-fold (0.60 log units) below it; measured number outside the range, above it.
By their numbers in this assay, from the lowest: compound 2; then compound 3; then compound 4; then compound 1.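

With 2-methoxyphenyl on the carbonyl carbon, the first six-membered aromatic ring of carbon only at this place, this assay gives a 2.6-fold higher number from compound 3 to compound 4 (0.41 log units; beyond the scatter), and measured against the unsubstituted furan the change is a 13-fold higher number from compound 2 to compound 4 (1.12 log units; beyond the scatter). This settles the direction that the earlier step could not give for such a ring: among these amides, both 4,5-dimethylfuran-2-yl and 2-methoxyphenyl read higher than furan-2-yl. Nothing available here accounts for the rise.

The compounds shown leave open whether the rise belongs to the six-membered ring itself or to its methoxy group, a question that a plain phenyl on the carbonyl carbon would address. They also leave open whether a thiophene, or a furan bearing an amine or a carboxylic acid, would read near compound 2 at 90 nM or further from it.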